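Benzyl ether substituent change in an acylurea series

A few compounds are considered here, and "the series" means these few. Any claim that something is new, unique, unknown or untested is made for them only; others in the source may bear on it.

Two members of the shared core have been measured so far. Among the compounds with values here, compound 1 `Cc1ccc(NC(=S)NC(=O)c2ccc(OCc3ccccc3Cl)cc2)cc1-c1nc2ccccc2[nH]1` and compound 2 `Cc1ccc(NC(=O)NC(=O)c2ccc(OCc3cccc(Cl)c3)cc2)cc1-c1nc2ccccc2[nH]1` differ from each other in more than one place, so no single-point step can be drawn between them. In a functional assay on HT-29 cells (Homo sapiens) for inhibition, read by MTT assay, with a stated time of 48 h (a lower number here means a stronger inhibitor, a higher number a weaker inhibitor), compound 1 gives 23700 nM. In this assay compound 2 gives 15400 nM, the lower of the two numbers, but the gap to compound 1 lies within the scatter of repeated measurements of this kind, so neither compound can be called the stronger inhibitor on these data.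

Compound 3 `Cc1ccc(NC(=O)NC(=O)c2ccc(OCc3cccc(C(F)(F)F)c3)cc2)cc1-c1nc2ccccc2[nH]1` is the next member. It differs from compound 2 in a single place: trifluoromethyl in place of chloro on an aromatic carbon. Within the data shown here, no measured pair shows what this exchange does, so the expectation rests only on the value of compound 2 and on the size of the change itself. For compound 3 the expected step is a 1.0-fold lower number from compound 2 to compound 3 (0.01 log units; within the scatter), a small one that is not expected to reach beyond the scatter. Compound 3 is therefore estimated at 15000 nM in this assay, with a range from 6000 nM to 40000 nM.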

Compound 3, half-maximal inhibitory concentration: 3520 nM
Compound 3: middle estimate off by 4.3-fold (0.63 log units), on the high side; the whole stated range lies above it.
By their numbers in this assay, from the lowest: compound 3; then compounds 2 and 1 (each within the scatter of the next).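

At this place on the ring, meta to a large group, this assay now gives the series its first step that can be read at a single point: a 4.4-fold lower number from compound 2 to compound 3 (0.64 log units; beyond the scatter) when chloro gives way to trifluoromethyl. The position is thus not indifferent to its substituent, even though the exchange involves no ring, no charge and no hydrogen-bond donor or acceptor on either side, only a move from 1 heavy atom to 4 heavy atoms. This single pair shows that the step occurs, but nothing available bears on what lies behind it.

Still open, on these data alone, is whether the step follows the size of the group or something specific to trifluoromethyl: a methyl, a methoxy, a nitrile or an amine at the same place would help separate these readings. Also open, as far as these compounds go, is whether the exchange gives a step of similar size at other places on this ring or in the thiourea form seen in compound 1, which differs from compound 2 in more than one place.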